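A few compounds are considered here, and "the series" means these few. Any claim that something is new, unique, unknown or untested is made for them only; others in the source may bear on it.

Cytotoxicity was followed in a functional assay on P388 cells (Mus musculus) for cytotoxicity; a lower number here means that less compound is needed, a higher number that more compound is needed for the effect. Compound 1 `Oc1ccc2nc(-c3ccccc3)cc(O)c2c1` gives 2.86 ug/mL in this assay, and compound 2 `Oc1ccc2c(O)cc(-c3ccccc3)nc2c1` gives 0.81 ug/mL. Compound 3 `COCOc1ccc(-c2cc(=O)c3ccccc3n2C)cc1` is different in kind: for it this assay reports only a limit, > 10 ug/mL, so no number is known for compound 3 (the limit of > 10 ug/mL in this assay, at which 1 of the 3 values shown sits). Compound 4 `Cn1c(-c2ccc(O)cc2)cc(=O)c2ccccc21` differs from compound 3 by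

hydrogen in place of methoxymethyl on an oxygen on an aromatic ring

Among the measured compounds shown here, no measured pair of compounds shows this change, so no measured step tells its direction. With compound 3 at a limit, the change is expected to bring compound 4 into the measurable range, with a downward step expected as an at least 1.2-fold lower number from compound 3 to compound 4 (0.09 log units; that floor lies within the scatter), though uncertainty remains wide. Compound 4 is expected to give about 8 ug/mL, between 2 ug/mL and 30 ug/mL.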

Compound 4, half-maximal effective concentration: > 10 ug/mL
Compound 4 ended at the assay's limit (the forecaster's own chance of this, stated with the estimate: 40%); middle value at least 1.2-fold (0.09 log units) from the limit.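

Compound 3 and compound 4 both stand only at a limit in this assay, so no step can be read from one to the other: the limit of > 10 ug/mL in this assay, at which 2 of the 4 values shown sit.

Whether hydrogen in place of methoxymethyl changes the cytotoxicity of these compounds at all remains open.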